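The source may report more compounds than this note shows. Statements on the series, on what has been measured and on what is new or still open speak of the compounds shown alone.

Series notes. Compound 1 `CCCC(=O)c1ccc(OCCCCOc2ccc(F)c(C(=O)O)c2)c(C)c1O` gives 56.9% in an assay on HEK293 cells for positive allosteric modulation of metabotropic glutamate receptor 3 (Rattus norvegicus), read by thallium flux, with a stated time of 2.5 min; on this read-out lower numbers stand for smaller maximal responses and higher numbers for larger maximal responses. Compound 3 `CCC(=O)c1ccc(OCCCCOc2ccc(F)c(C(=O)O)c2)c(C)c1O` gives 18.4% in this assay, and compound 2 `COc1cc(C(=O)O)ccc1OCCCCOc1ccc(C(=O)CC(C)C)c(O)c1C` gives 73.9%, the highest of the three. The step of a number 38.5 percentage points higher from compound 3 to compound 1 (beyond the scatter) goes with methyl in place of hydrogen on a saturated chain carbon, two bonds along the chain from a carbonyl carbon.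

Compound 4 `COc1cc(C(=O)O)ccc1OCCCCOc1ccc(C(=O)CC(C)(C)C)c(O)c1C` is not yet measured. It differs from compound 2 by methyl in place of hydrogen on a saturated chain carbon bound to three saturated chain carbons. The difference between the core of compound 2 and the core of compound 3 is not broken down here. The change from compound 2 to compound 4 is the same kind of change as from compound 3 to compound 1, but not the same: in one case the new methyl sits on a saturated chain carbon, two bonds along the chain from a carbonyl carbon; in the other on a saturated chain carbon bound to three saturated chain carbons. Among the compounds with values here, the one measured example of a methyl entering, a number 38.5 percentage points higher from compound 3 to compound 1 (beyond the scatter), was a large rise; whether that carries to a carbon already bound to three saturated chain carbons is untested. The step from compound 2 to compound 4 in this assay is therefore expected to be smaller, a number 4.1 percentage points higher from compound 2 to compound 4 (within the scatter), wide in uncertainty. Compound 4 is estimated at 78%, between 55% and 98%.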

Compound 4, largest response reached (reported as percent of maximum), in percent of the reference or control that the assay uses: 109%
Estimate against measurement, compound 4: 31 percentage points below; measured number outside the range, above it.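

In this assay, the added methyl gives a number 35.1 percentage points higher from compound 2 to compound 4 (beyond the scatter), and this large rise sits level with the earlier step on the other core: the same change on two cores in this assay, a number 38.5 percentage points higher (beyond the scatter) from compound 3 to compound 1 and a number 35.1 percentage points higher (beyond the scatter) from compound 2 to compound 4, 3.4 percentage points apart, within the scatter of two such steps

So, across these two pairs, adding one methyl to the chain on the carbonyl carbon raises the maximal response by a similar amount on both cores, even though the new methyl sits on a differently substituted carbon in each pair. This shows that the change carried over in this one case, but two pairs do not establish a rule for the series, and they do not show which feature of the chain is responsible or how the change would behave on any third core.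

On these data alone, it remains open whether the rise continues with a longer chain or with a cyclopropyl or cyclohexyl ring in place of the neopentyl group. As far as these compounds go, the effect of an amide or a tetrazole in place of the carboxylic acid on these chains is also open.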